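Trimethoxyphenyl variant of a pyrazoline sulfonamide series

The compounds below may be only part of what the source reports. "The series", "measured", "known", "first", "only" and "open" are said of these compounds alone.

Measured so far in a functional assay on 786-0 cells (Homo sapiens) for antiproliferative activity, with a stated time of 48 h; on this read-out lower numbers stand for stronger inhibition of growth and higher numbers for weaker inhibition of growth:
Compound 1, `Cc1cc(O)c(C2=NN(c3ccc(S(N)(=O)=O)cc3)C(c3ccccc3Cl)C2)cc1Cl`, gives 2250 nM.
Compound 2, `Cc1cc(O)c(C2=NN(c3ccc(S(N)(=O)=O)cc3)C(/C=C/c3ccccc3)C2)cc1Cl`, gives 4090 nM.
Compound 3, `COc1ccc(C2CC(c3cc(Cl)c(C)cc3O)=NN2c2ccc(S(N)(=O)=O)cc2)cc1OC`, gives 2370 nM.

Three compounds share a core and differ only in the aryl or alkenyl group on a saturated ring carbon. Their numbers in this assay lie close together: a 1.8-fold higher number from compound 1 to compound 2 (0.26 log units; within the scatter), a 1.1-fold higher number from compound 1 to compound 3 (0.02 log units; within the scatter), and a 1.7-fold lower number from compound 2 to compound 3 (0.24 log units; within the scatter). Compound 3 thus stands second highest of the three, closest to compound 1 and furthest from compound 2, with every gap inside the scatter.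

Compound 4, `COc1ccc(C2CC(c3cc(Cl)c(C)cc3O)=NN2c2ccc(S(N)(=O)=O)cc2)c(OC)c1OC`, is not yet measured. It differs from compound 3 in one place: methoxy in place of hydrogen on an aromatic carbon. Among the compounds with values here, no measured step adds a methoxy group to this ring; the steps that bear on the question are the swaps of the whole group at this ring carbon, and each of those left the number within the scatter. A change confined to one substituent on that ring is therefore expected to be no larger. The expected step is a 1.1-fold higher number from compound 3 to compound 4 (0.02 log units; within the scatter). Compound 4 is estimated to give 2500 nM, in a range from 1000 nM to 6500 nM.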

Compound 4, concentration for 50% growth inhibition: 2210 nM
Estimate against measurement, compound 4: 1.1-fold (0.05 log units) above, within the range that was stated.
By their numbers in this assay, from the lowest: compounds 4, 1, 3 and 2 (each within the scatter of the next).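

In this assay, within the data shown here, this is the first step that adds a single substituent to the ring rather than swapping the whole group at the saturated ring carbon: methoxy in place of hydrogen, on an aromatic carbon ortho to a large group and ortho to a methoxy group, gives a 1.1-fold lower number from compound 3 to compound 4 (0.03 log units; within the scatter). The fuller 2,3,4-trimethoxyphenyl group also sits within the scatter of the other two groups at that ring carbon, with a 1.9-fold lower number from compound 2 to compound 4 (0.27 log units; within the scatter) against 2-phenylethenyl and a 1.0-fold lower number from compound 1 to compound 4 (0.01 log units; within the scatter) against 2-chlorophenyl, so none of the four compounds separates from the others on this read-out. Nothing at hand explains why this position tolerates the extra methoxy group in this assay.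

The compounds shown leave open whether an amine, a carboxylic acid or a longer chain such as butoxy on this aromatic carbon would carry the number beyond the scatter. They also leave open whether a methoxy group here would give the same result on a ring without the two other methoxy groups, as none of the compounds has that arrangement.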